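The compounds below may be only part of what the source reports. "The series", "measured", "known", "first", "only" and "open" are said of these compounds alone.

Compound 1 `COc1ccc(Br)c(-c2nc3ncccc3o2)c1` holds the lower of the two numbers recorded in a functional assay on the whole organism for inhibition, with Rattus norvegicus as the target, at a dose of 30 mg/kg (a higher number here means more inhibition at the dose given (going by the name of the read-out), a lower number less inhibition), where compound 1 gives 8%. Compound 2 `N#Cc1cccc(C#N)c1-c1nc2ncccc2o1` shares the core, and in this assay compound 2 gives 19%, a number that stands beyond the scatter above compound 1. Compound 3 `COc1cccc(-c2nc3ncccc3o2)c1` differs from compound 1 in one place: hydrogen in place of bromo on an aromatic carbon. For the measured compounds named here, no step between two measured compounds carries this change, so its effect is unknown; a step within the scatter, or one of small size in either direction, is expected. The expected step is a number 4 percentage points higher from compound 1 to compound 3 (within the scatter). Compound 3 is estimated to give 12%, between 0% and 35%.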

Compound 3, a percentage reported as inhibition, in the whole organism at one dose (the size of the read-out at that dose, not a potency): 14%
For compound 3 the middle estimate is 2 percentage points below the measured one; measured number inside the range.
By their numbers in this assay, from the lowest: compounds 1, 3 and 2 (each within the scatter of the next, the first and the last beyond it).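

In this assay, for the compounds shown here, the step of a number 6 percentage points higher from compound 1 to compound 3 (within the scatter) is the first direct reading of this change, hydrogen in place of bromo on the aromatic carbon para to a methoxy group. At this dose, the read-out does not separate bromo from hydrogen at this position. No measurement on hand accounts for the step.

As far as these compounds go, whether an amine, a carboxylic acid or a longer chain at this position would shift the inhibition remains open, as does the effect of replacing the methoxy group itself.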